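Opening a ring on the thiazolidinone nitrogen

This account rests on a few compounds, and the source may have more. Where it says the series, first, only, none or still open, it means among the compounds named here.

Compound 2: `CCCC[C@H](NC(=O)[C@H](CCCCN)NC(=O)[C@H](CCCNC(=N)N)NC(=O)c1ccc(/C=C2\SC(=S)N(C3CCCC3)C2=O)cc1)C(N)=O`, 2.31 10^-6 cm/s
Compound 1: `CCCC[C@H](NC(=O)[C@H](CCCCN)NC(=O)[C@H](CCCNC(=N)N)NC(=O)c1ccc(/C=C2\SC(=O)N(CCCC)C2=O)cc1)C(N)=O`, 1.18 10^-6 cm/s

Among the compounds with values here, in an ADME assay for permeability, using PAMPA (a lower number here means that the compound crosses the layer more slowly, a higher number that the compound crosses the layer faster), compound 2 gives 2.31 10^-6 cm/s, and compound 1 gives 1.18 10^-6 cm/s; the two numbers lie within the scatter of each other, and since the two structures differ in more than one place, no single step joins them. Compound 3 is `CCCC[C@H](NC(=O)[C@H](CCCCN)NC(=O)[C@H](CCCNC(=N)N)NC(=O)c1ccc(/C=C2\SC(=S)N(CCCC)C2=O)cc1)C(N)=O`. It differs from compound 2 by butyl in place of cyclopentyl on an amide-type nitrogen in a ring. Within the data shown here, with no measured step of this kind to lean on, the expectation for compound 3 in this assay is a change of a 1.4-fold lower number from compound 2 to compound 3 (0.13 log units; within the scatter), not beyond the scatter. Compound 3 is estimated at 1.7 10^-6 cm/s, within 0.9 10^-6 cm/s to 3.2 10^-6 cm/s.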

Compound 3, apparent permeability: 1.61 10^-6 cm/s
The estimate for compound 3 lay 1.1-fold (0.02 log units) above the measured number, within the range that was stated.
By their numbers in this assay, from the lowest: compounds 1, 3 and 2 (each within the scatter of the next).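

In this assay the change from cyclopentyl to butyl on the amide-type nitrogen in a ring gives a 1.4-fold lower number from compound 2 to compound 3 (0.16 log units; within the scatter) and so gives this position its first single-place step, one that stays within the scatter. With butyl present in both compounds, the exchange of the ring group gives a 1.4-fold higher number from compound 1 to compound 3 (0.13 log units; within the scatter) and also stays within the scatter. No measurement at hand offers a reason for these numbers. Still open, from the compounds shown here alone, is whether an amine, a carboxylic acid or a longer chain on this nitrogen would give a step beyond the scatter.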